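Dimethylamino for acetyl on the pendant phenyl ring

This account rests on a few compounds, and the source may have more. Where it says the series, first, only, none or still open, it means among the compounds named here.

Measured so far, all in a functional assay on TK-10 cells (Homo sapiens) for inhibition, read by sulforhodamine B assay, with a stated time of 48 h; on this read-out lower numbers stand for higher toxicity in this test and higher numbers for lower toxicity in this test:
compound 1 `COc1cc(C)cc(-c2c(-c3ccnc(-c4ccc(C(C)=O)cc4)c3)cnn2CC#N)c1` gives > 100000 nM.
compound 2 `COc1cc(C)cc(-c2nn(CC#N)cc2-c2ccc(-c3cccc(C(C)=O)c3)nc2)c1` gives > 100000 nM.
compound 3 `COc1cc(C)cc(-c2nn(CC#N)cc2-c2ccnc(-c3ccc(N(C)C)cc3)c2)c1` gives > 100000 nM.

Every value written here is a limit of this assay, not a number: compound 1 reaches only the limit > 100000 nM in this assay. Going by the values given here, compound 2 and compound 3 sit at the same limit, so that all three results share (the limit of > 100000 nM in this assay, at which 3 of the 3 values shown sit), and no step between any two of them can be read. Compound 1 therefore stands nowhere in particular on the numbers shown; it is simply one of three compounds that did not reach a lethal concentration within the tested range.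

Compound 4 `COc1cc(C)cc(-c2c(-c3ccnc(-c4ccc(N(C)C)cc4)c3)cnn2CC#N)c1` is the next member. It differs from compound 1 by dimethylamino in place of acetyl on an aromatic carbon. Compound 3 carries the same 4-(dimethylamino)phenyl group on a core arranged differently and also returned only the limit, which gives no sign that this group by itself brings the value down into the measurable range.

Expectation: no step beyond the scatter from compound 1 to compound 4 in this assay, so a number no higher from compound 1 to compound 4 (the limit leaves the size open) is estimated as essentially none, with the most likely outcome again a limit. Compound 4 is expected at 100000 nM, within 30000 nM to 300000 nM.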

Compound 4, concentration lethal to 50% of the cells: > 100000 nM
Compound 4 gave a limit, no number (the forecaster's own chance of this, stated with the estimate: 85%); the middle value sits exactly at the limit.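

The step between compound 1 and compound 4 cannot be read, since both return only a limit in this assay: the limit of > 100000 nM in this assay, at which 4 of the 4 values shown sit.

The compounds shown leave open whether dimethylamino in place of acetyl on an aromatic carbon shifts the lethal concentration at all, and where any of the four compounds would fall as an actual number.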